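Swapping the Ring for a Fluorinated Chain

The source may report more compounds than this note shows. Statements on the series, on what has been measured and on what is new or still open speak of the compounds shown alone.

Two compounds share one core. Compound 1 `CC(C)CCOc1c(C(=O)N(C)Cc2cc(C(F)(F)F)cc(C(F)(F)F)c2)c(=O)n(C)c2ccccc12` carries an isopentyloxy group, and compound 2 `CN(Cc1cc(C(F)(F)F)cc(C(F)(F)F)c1)C(=O)c1c(N2CCCCC2)c2ccccc2n(C)c1=O` carries piperidin-1-yl in its place. In an ADME assay for inhibition of phosphatidylcholine:ceramide cholinephosphotransferase 1 (Homo sapiens), read by mass spectrometry, with stated times of 60 min and 30 min (a higher number here means a weaker inhibitor, a lower number a stronger inhibitor), compound 1 gives only a limit of the assay, > 100000 nM. In this assay compound 2 likewise gives only a limit, > 100000 nM. The step from one to the other is a step that the two limits leave unreadable from compound 1 to compound 2, so it cannot be read. Compound 2 thus stands at the limit of > 100000 nM in this assay, at which 2 of the 2 values shown sit, together with every value shown so far. Compound 3 `CN(Cc1cc(C(F)(F)F)cc(C(F)(F)F)c1)C(=O)c1c(OCCCC(F)(F)F)c2ccccc2n(C)c1=O` differs from compound 2 by 4,4,4-trifluorobutoxy in place of piperidin-1-yl on an aromatic carbon. Within the data shown here, the single measured step bears on this change, but its size is unreadable, so it gives no direction. Because the two measured values sit at the limit of > 100000 nM in this assay, at which 2 of the 2 values shown sit, compound 3 is expected to stay there as well, the step that the limit leaves unreadable from compound 2 to compound 3 being no larger than scatter. The estimate for compound 3 is 200000 nM, within 50000 nM and 1000000 nM.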

Compound 3, half-maximal inhibitory concentration: 25000 nM
Beside the measured number, compound 3's estimate is 8.0-fold (0.90 log units) above it; the whole stated range lies above it.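

In this assay, this aromatic carbon, opposite the ring nitrogen, turns out to respond to what it carries: 4,4,4-trifluorobutoxy in place of piperidin-1-yl gives an at least 4.0-fold lower number from compound 2 to compound 3 (0.60 log units; beyond the scatter). An oxygen-linked chain alone is not enough, since compound 1 has one too; 2,2,2-trifluoroethyl in place of isopropyl on the chain, two bonds along from the oxygen, gives an at least 4.0-fold lower number from compound 1 to compound 3 (0.60 log units; beyond the scatter). Both steps give only a minimum size and not a full one, because each starts from a compound held at a limit: the limit of > 100000 nM in this assay, at which 2 of the 3 values shown sit.

A plain butoxy chain would be needed to separate the part played by the chain from that of its three fluorine atoms. From the compounds shown here alone, it also remains open how the number would move with a longer fluorinated chain, or with a chain ending in a carboxylic acid.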